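The source may report more compounds than this note shows. Statements on the series, on what has been measured and on what is new or still open speak of the compounds shown alone.

In an assay on C6 glioma cells for displacement of a labelled ligand from sodium- and chloride-dependent glycine transporter 1 (Rattus norvegicus), read by scintillation counting, with stated times of 30 min and 10 min (a higher number here means a weaker inhibitor, a lower number a stronger inhibitor), the measured set is short:

compound 1 `CCc1nnc(-c2ccc(-c3ccccc3)cc2)n1-c1cccc(CO)c1C` gives 250 nM;
compound 2 `CCc1nnc(-c2ccc(-c3ccccc3)cc2)n1-c1cccc(F)c1C` gives 630 nM;
compound 3 `CCc1nnc(-c2ccc(-c3ccccc3)cc2)n1-c1cccc(Cl)c1C` gives 2200 nM.

Compound 3 thus carries the highest number of the three, with a 3.5-fold higher number from compound 2 to compound 3 (0.54 log units; beyond the scatter) and an 8.8-fold higher number from compound 1 to compound 3 (0.94 log units; beyond the scatter). Compound 4 `CCc1nnc(-c2ccc(-c3ccccc3)cc2)n1-c1cccc(C(N)=O)c1C` differs from compound 3 in one place: carbamoyl in place of chloro on an aromatic carbon. For the measured compounds named here, the step that bears most on this change is the one from compound 1 to compound 3, an 8.8-fold higher number from compound 1 to compound 3 (0.94 log units; beyond the scatter), where the only non-halogen substituent in the set was exchanged for chloro, and its reversal here points toward a lower number; the smaller step of a 3.5-fold higher number from compound 2 to compound 3 (0.54 log units; beyond the scatter) adds the same direction. For compound 4 a value of 350 nM is therefore expected, within 120 nM to 1000 nM, which means an expected step of a 6.3-fold lower number from compound 3 to compound 4 (0.80 log units; beyond the scatter).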

Compound 4, half-maximal inhibitory concentration: 3900 nM
The estimate for compound 4 lay 11-fold (1.05 log units) below the measured number, outside the stated range (above it).
By their numbers in this assay, from the lowest: compound 1; then compound 2; then compounds 3 and 4 (each within the scatter of the next).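

In this assay, carbamoyl and chloro on this aromatic carbon cannot be told apart, with a 1.8-fold higher number from compound 3 to compound 4 (0.25 log units; within the scatter). For the compounds shown here, a non-halogen group here therefore does not by itself give a lower number, which the earlier compounds could not show. Hydroxymethyl and carbamoyl, the two non-halogen groups, stand far apart, with a 16-fold higher number from compound 1 to compound 4 (1.19 log units; beyond the scatter), and fluoro also separates from carbamoyl, with a 6.2-fold higher number from compound 2 to compound 4 (0.79 log units; beyond the scatter).

Nothing measured here accounts for this gap. Going by these compounds, it remains open whether an amine, a carboxylic acid or a longer chain such as hydroxyethyl would fall nearer hydroxymethyl or carbamoyl.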